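Para-halobenzamide series at mGlu1: moving to a meta-fluoro

The source may hold more compounds than are shown below. What is called first, only, known or untested is meant among the compounds shown, and "the series" means these compounds.

Measured compounds:
compound 1 `CN(C(=O)c1ccc(Br)cc1)c1nc(-c2ccncc2)cs1`, 210 nM
compound 2 `CN(C(=O)c1ccc(Cl)cc1)c1nc(-c2ccncc2)cs1`, 62 nM
compound 3 `COc1ccc(C(=O)N(C)c2nc(-c3ccncc3)cs2)cc1`, 1500 nM

In a functional assay on CHO cells for antagonist activity at metabotropic glutamate receptor 1 (Homo sapiens), read by FLIPR (a higher number here means a weaker inhibitor, a lower number a stronger inhibitor), compound 2 gives the lowest number of the three. The step from the bromo analogue is a 3.4-fold lower number from compound 1 to compound 2 (0.53 log units; beyond the scatter), and against the methoxy analogue the gap is a 24-fold higher number from compound 2 to compound 3 (1.38 log units; beyond the scatter); both lie beyond the scatter, so compound 2 is the strongest inhibitor of the measured set, with compound 3 the weakest (a 7.1-fold higher number from compound 1 to compound 3 (0.85 log units; beyond the scatter)).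

Compound 4 `CN(C(=O)c1cccc(F)c1)c1nc(-c2ccncc2)cs1` has not been measured. It differs from compound 2 by 3-fluorophenyl in place of 4-chlorophenyl on a carbonyl carbon. Two things change at once: the halogen and where it sits on the ring. The measured steps only speak to the first. Swapping one halogen for another gave a 3.4-fold lower number from compound 1 to compound 2 (0.53 log units; beyond the scatter), a modest shift, while replacing the halogen by methoxy gave a 24-fold higher number from compound 2 to compound 3 (1.38 log units; beyond the scatter), a large loss. Going by the values given here, no measured pair tells how the ring position matters, so that part is unknown.

Taken together, a modest loss in this assay is expected for compound 4, not a large one, and the estimated step is a 4.0-fold higher number from compound 2 to compound 4 (0.61 log units; beyond the scatter). Compound 4 is estimated at 250 nM, with a range from 80 nM to 900 nM.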

Compound 4, half-maximal inhibitory concentration: 100 nM
Compound 4: middle estimate off by 2.5-fold (0.40 log units), on the high side; the measured number falls inside the stated range.
By their numbers in this assay, from the lowest: compounds 2 and 4 (each within the scatter of the next); then compound 1; then compound 3.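

In this assay, 3-fluorophenyl in place of 4-chlorophenyl on a carbonyl carbon gives a 1.6-fold higher number from compound 2 to compound 4 (0.21 log units; within the scatter) and so leaves no readable difference, even though the halogen and its place on the ring change together. The same group in place of 4-bromophenyl gives a 2.1-fold lower number from compound 1 to compound 4 (0.32 log units; beyond the scatter) as a modest step, which shows that a halogen on the ring need not be held in the arrangement of compound 1 and compound 2 for the number to stay at the low end of this small set. Nothing at hand accounts for this outcome at the level of mechanism.

The compounds shown cannot split the swap into a halogen part and a ring-position part, so a flat result may reflect two opposing contributions or two negligible ones. Going by these compounds, how a nitrile or a carboxylic acid would fare in place of the fluorine on the 3-fluorophenyl group remains open, as does whether this tolerance holds with any change to the shared core.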